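This account rests on a few compounds, and the source may have more. Where it says the series, first, only, none or still open, it means among the compounds named here.

Measured compounds in an ADME assay on MDCK cells (Canis lupus familiaris) for cytotoxicity, read by microscopy, with a stated time of 48 h; on this read-out lower numbers stand for higher toxicity in this test and higher numbers for lower toxicity in this test:
compound 1 `C[C@H]1[C@H](NCc2cncs2)C[C@H]2C[C@@H]1C2(C)C`, compound 2 `C[C@H]1[C@H](NCc2ccc(Br)s2)C[C@H]2C[C@@H]1C2(C)C`, compound 3 `C[C@H]1[C@H](NCc2cc(Br)cs2)C[C@H]2C[C@@H]1C2(C)C`.

Compound 1 reaches only the limit > 100000 nM in this assay. Compound 2 gives 43000 nM in this assay, and compound 3 gives 6250 nM in this assay, the lowest number shown, with compound 2 the nearest value: a 6.9-fold lower number from compound 2 to compound 3 (0.84 log units; beyond the scatter).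

Compound 4 `C[C@H]1[C@H](NCc2cncnc2)C[C@H]2C[C@@H]1C2(C)C` differs from compound 3 as follows: pyrimidin-5-yl in place of 4-bromothiophen-2-yl on a saturated chain carbon bound to an amine nitrogen. Among the measured compounds shown here, two steps bear on this: an at least 16-fold lower number from compound 1 to compound 3 (1.20 log units; beyond the scatter) and a 6.9-fold lower number from compound 2 to compound 3 (0.84 log units; beyond the scatter), both lowering the number on arrival at 4-bromothiophen-2-yl. Leaving that group is therefore expected to raise the number, by a step estimated as a 9.6-fold higher number from compound 3 to compound 4 (0.98 log units; beyond the scatter). Compound 4 is expected to give about 60000 nM in this assay, in the range 15000 nM to 150000 nM, with a fair chance that only a limit is reported, as for compound 1 (the limit of > 100000 nM in this assay, at which 1 of the 3 values shown sits).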

Compound 4, minimum cytotoxic concentration: > 100000 nM
Compound 4 ended at the assay's limit; the forecaster's own chance of this, stated with the estimate: 40%; at least 1.6-fold (0.22 log units) between middle value and limit.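

In this assay, the six-membered pyrimidin-5-yl ring shows that the low numbers at this place do not extend to every aromatic ring: an at least 16-fold higher number from compound 3 to compound 4 (1.20 log units; beyond the scatter), and an at least 2.3-fold higher number from compound 2 to compound 4 (0.36 log units; beyond the scatter). Among the four compounds, only the two bromothiophenes give readable numbers, and both non-brominated rings end at the limit. The step between compound 1 and compound 4 cannot be read: the limit of > 100000 nM in this assay, at which 2 of the 4 values shown sit.

On these data alone, whether the lower numbers follow the bromine or the thiophene ring remains open. An unsubstituted thiophen-2-yl or a 4-chlorothiophen-2-yl would separate the two.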